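The source may report more compounds than this note shows. Statements on the series, on what has been measured and on what is new or still open speak of the compounds shown alone.

Measured compounds in a functional assay on MGC-803 cells (Homo sapiens) for inhibition, read by MTT assay, with a stated time of 72 h; a lower number here means a stronger inhibitor, a higher number a weaker inhibitor:
compound 1, `CN1CCN(C(=S)SCCCOc2ccc(C(=O)/C=C/c3ccc(Cl)cc3)cc2)CC1`, gives 29400 nM;
compound 2, `COc1cc(/C=C/C(=O)c2ccc(OCCCSC(=S)N3CCN(C)CC3)cc2)cc(OC)c1OC`, gives 7370 nM;
compound 3, `O=C(/C=C/c1ccc(Cl)cc1)c1ccc(OCCSC(=S)N2CCOCC2)cc1`, gives 11500 nM.

Compound 3 stands second highest of the three numbers in this assay; compound 2 lies within the scatter of it, while compound 1 sits beyond it. Compound 4, `O=C(/C=C/c1ccc(Cl)cc1)c1ccc(OCCSC(=S)N2CCCCC2)cc1`, differs from compound 3 in one place: piperidin-1-yl in place of morpholin-4-yl on a thiocarbonyl carbon. Among the measured compounds shown here, the only measured step, a 4.0-fold lower number from compound 1 to compound 2 (0.60 log units; beyond the scatter), concerns the 4-chlorophenyl to 3,4,5-trimethoxyphenyl exchange on the double-bonded chain carbon and not the ring on the thiocarbonyl carbon, so it does not bear on this change. For the measured compounds named here, no measured pair varies that ring at all. The step from compound 3 to compound 4 is therefore expected to stay within the scatter, no change at the digits printed from compound 3 to compound 4 (within the scatter). Compound 4 is estimated at 11500 nM, with a range from 4000 nM to 33000 nM.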

Compound 4, half-maximal inhibitory concentration: 12800 nM
Compound 4: middle estimate off by 1.1-fold (0.05 log units), on the low side; the range from low to high includes it.
By their numbers in this assay, from the lowest: compounds 2, 3 and 4 (each within the scatter of the next); then compound 1.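

In this assay the exchange of morpholin-4-yl for piperidin-1-yl on the thiocarbonyl carbon gives a 1.1-fold higher number from compound 3 to compound 4 (0.05 log units; within the scatter) and is the only measured variation of this ring. On this 4-chlorophenyl background, the ring oxygen and the hydrogen-bond acceptor counted with it can therefore go without a shift beyond the scatter. No supporting measurement bears on this result. Still open, on these data alone, is whether an open-chain dimethylamino group on the thiocarbonyl carbon would stay as close, and whether the same exchange holds with 3,4,5-trimethoxyphenyl in place of 4-chlorophenyl.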